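A few compounds are considered here, and "the series" means these few. Any claim that something is new, unique, unknown or untested is made for them only; others in the source may bear on it.

Working notes on the series. Compound 1 `CCC[C@@H]1CN[C@H](C(=O)N2CCC[C@H]2C#N)C1` has the lower of the two measured numbers in an assay on the whole organism (plasma, strain Sprague-Dawley) for inhibition of Dipeptidyl peptidase 4 (Rattus norvegicus), with a stated time of 6 h, at a dose of 1 mg/kg by the oral route; on this read-out higher numbers stand for more inhibition at the one dose given (going by the name of the read-out) and lower numbers for less inhibition: compound 1 gives 50%, whereas compound 2 `C[C@@H]1N[C@H](C(=O)N2CCC[C@H]2C#N)C[C@@H]1C(=O)N1CCSCC1` gives 92%, a gap well beyond the usual scatter. Compound 3 `N#C[C@@H]1CCCN1C(=O)[C@@H]1C[C@H](C(N)=O)CN1` is the unmeasured entry that follows from compound 1 by a single change, (carbamoyl in place of propyl on a saturated ring carbon). For the measured compounds named here, no pair of measured compounds differing in one place is available, so the size of this step rests on the two readings alone. Going by the values given here, compound 2 differs from compound 1 in more than one place, so its higher reading shows only that a compound substituted in that way on the shared core reaches a higher number in this assay. An upward step a number 18 percentage points higher from compound 1 to compound 3 (beyond the scatter) is expected, but of uncertain size. Compound 3 is estimated at 68% in this assay, with a range from 40% to 92%.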

Compound 3, a percentage reported as inhibition, in the whole organism at one dose (the size of the read-out at that dose, not a potency): 47%
Beside the measured number, compound 3's estimate is 21 percentage points above it; measured number inside the range.
By their numbers in this assay, from the lowest: compounds 3 and 1 (each within the scatter of the next); then compound 2.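

In this assay, for the compounds shown here, the step of carbamoyl in place of propyl on a saturated ring carbon, two ring bonds from the ring nitrogen, is a number 3 percentage points lower from compound 1 to compound 3 (within the scatter) and gives the first single-place reading at this position. At this one dose, the exchange of an all-carbon chain for a group carrying a hydrogen-bond donor and a hydrogen-bond acceptor therefore does not separate the two compounds. No measurement at hand accounts for this outcome.

From the compounds shown here alone, whether another group on the same ring carbon, such as an amine, a carboxylic acid or a longer chain, would give a step beyond the scatter remains open. Also open, going by these compounds, is whether compound 1 and compound 3 would still read alike at other doses or times, as a single-dose percentage is not a potency.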